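Taking the fluoro group off compound 3

The source may hold more compounds than are shown below. What is called first, only, known or untested is meant among the compounds shown, and "the series" means these compounds.

Of the compounds shown here, three sharing one core have been tested in a functional assay on SGC-7901 cells (Homo sapiens) for antiproliferative activity, read by sulforhodamine B assay, with a stated time of 72 h; a higher number here means a weaker inhibitor, a lower number a stronger inhibitor. Compound 1 (`FC(F)(F)c1ccccc1NC(=S)N/N=C/c1ccc2ccccc2n1`) gives 20700 nM, compound 2 (`S=C(N/N=C/c1ccc2ccccc2n1)Nc1ccc(Cl)cc1`) gives 87600 nM, and compound 3 (`Fc1ccc(NC(=S)N/N=C/c2ccc3ccccc3n2)cc1`) gives 32300 nM. Compound 3 therefore lies within the usual scatter of compound 1 and clearly under compound 2.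

Compound 4 (`S=C(N/N=C/c1ccc2ccccc2n1)Nc1ccccc1`) differs from compound 3 in one place, with hydrogen in place of fluoro on an aromatic carbon. Going by the values given here, only one measured step bears on this change. Fluoro in place of chloro gave a 2.7-fold lower number from compound 2 to compound 3 (0.43 log units; beyond the scatter), a modest step beyond the scatter. Among the compounds with values here, that step swapped one group for another, whereas here the group is replaced by hydrogen, so the data offer no direct precedent and no firm direction. A step within the scatter is the most reasonable expectation, though a larger one cannot be excluded.

The expected step is a 1.1-fold lower number from compound 3 to compound 4 (0.03 log units; within the scatter). For compound 4 the estimated value is 30000 nM, with an expected range from 12000 nM to 80000 nM.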

Compound 4, half-maximal inhibitory concentration: 26500 nM
Beside the measured number, compound 4's estimate is 1.1-fold (0.05 log units) above it; measured number inside the range.
By their numbers in this assay, from the lowest: compounds 1, 4 and 3 (each within the scatter of the next); then compound 2.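

With the substituent gone, compound 4 gives a hydrogen baseline in this assay, and 4-fluorophenyl to phenyl makes no readable difference (a 1.2-fold lower number from compound 3 to compound 4 (0.09 log units; within the scatter)). Trifluoromethyl likewise stays within the scatter of hydrogen (a 1.3-fold higher number from compound 1 to compound 4 (0.11 log units; within the scatter)), so only the chloro compound stands apart from this baseline, and it goes against any idea that a substituent on this ring makes no difference (a 3.3-fold lower number from compound 2 to compound 4 (0.52 log units; beyond the scatter)). Nothing measured here explains why chloro separates from hydrogen while fluoro does not.

From the compounds shown here alone, whether an amine, a hydroxyl or a carboxylic acid on the same aromatic carbon would also match hydrogen or would separate from it remains open. Also open, going by these compounds, is whether any group on this ring could bring the number well under that of compound 4.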